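Cyclopropylmethyl for Isopropylsulfonyl: Expected Shift in Cytotoxicity

The compounds below may be only part of what the source reports. "The series", "measured", "known", "first", "only" and "open" are said of these compounds alone.

Compound 1 `CS(=O)(=O)c1ccc(Cn2c(=O)n(Cc3nc4ccccc4n3CCCC#N)c3ccncc32)cc1`: in an ADME assay on HEp-2 cells (Homo sapiens) for cytotoxicity (a lower number here means that less compound is tolerated, a higher number that more compound is tolerated), compound 1 gives 40900 nM.
Compound 2 `CC(C)S(=O)(=O)n1c(=O)n(Cc2nc3ccccc3n2CCCC#N)c2cnccc21`: in this assay compound 2 is reported only as a limit, > 228000 nM.
Compound 3 `O=c1n(Cc2nc3ccccc3n2CCCC(F)(F)F)c2cnccc2n1C1CC1`: in this assay compound 3 gives 55700 nM.

Compound 2 thus stands apart from the other two measured compounds in that no number is known for it, only a limit; this is the limit of > 228000 nM in this assay, at which 1 of the 3 values shown sits. Compounds 1 and 3, in contrast, each give a definite value, and those two values lie within the usual scatter of one another.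

Compound 4 `N#CCCCn1c(Cn2c(=O)n(CC3CC3)c3ccncc32)nc2ccccc21` has not yet been measured. It differs from compound 2 in one place: cyclopropylmethyl in place of isopropylsulfonyl on an aromatic nitrogen. Among the measured compounds shown here, no single-site step between measured compounds is available to calibrate this change. Even so, both compounds that gave a definite value in this assay fall well short of the limit reported for compound 2, so the step is expected to run downward, meaning that less of compound 4 would be tolerated than the limit of compound 2 allows, with a size that is expected to lie beyond the scatter, as an at least 4.5-fold lower number from compound 2 to compound 4 (0.65 log units; beyond the scatter).

Compound 4 is therefore estimated to reach 50000 nM in this assay, within a range from 15000 nM to 200000 nM.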

Compound 4, half-maximal cytotoxic concentration: 96500 nM
Compound 4: middle estimate off by 1.9-fold (0.29 log units), on the low side; low and high end bracket the measured number.
By their numbers in this assay, from the lowest: compounds 1, 3 and 4 (each within the scatter of the next, the first and the last beyond it). At a limit, above all of these: compound 2.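

Compound 2 is reported only as a limit, so the upper end of this comparison has no number: the limit of > 228000 nM in this assay, at which 1 of the 4 values shown sits. Compound 4 nevertheless gives the first single-site reading at this aromatic nitrogen in this assay, with cyclopropylmethyl in place of isopropylsulfonyl producing an at least 2.3-fold lower number from compound 2 to compound 4 (0.37 log units; beyond the scatter), so the position is shown to respond to this exchange, which the earlier compounds, none differing from another in one place, could not show. As far as these compounds go, the step gives only the smallest size the change can have, and its full size remains unknown; it also swaps a group with a sulfur, two oxygens and two hydrogen-bond acceptors for an all-carbon group with a three-membered ring and no acceptors.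

The compounds shown leave open which part of isopropylsulfonyl goes with the higher tolerated concentration, since a plain isopropyl group or an acetyl group on the same aromatic nitrogen would be needed to separate the alkyl part from the sulfonyl part. They also leave open whether the step would keep its direction with the nitrile chain replaced by another group.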